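This account rests on a few compounds, and the source may have more. Where it says the series, first, only, none or still open, it means among the compounds named here.

Compounds measured so far:
- compound 1 `O=C(Nc1cccc(-n2cc(-c3ccncc3)c(-c3ccc(Cl)c(O)c3)n2)c1)Nc1cccc(C(F)(F)F)c1`: 3180 nM
- compound 2 `COc1cc(-c2nn(-c3cccc(NC(=O)Nc4cc(C(F)(F)F)cc(C(F)(F)F)c4)c3)cc2-c2ccncc2)ccc1Cl`: 1120 nM

In a functional assay on OVCAR-4 cells (Homo sapiens) for inhibition, read by sulforhodamine B assay, with a stated time of 48 h (on this read-out lower numbers stand for stronger inhibition of growth and higher numbers for weaker inhibition of growth), compound 2 gives the lowest of the two numbers, and compound 1 lies beyond the scatter with its higher value. Compound 3 `O=C(Nc1cccc(-n2cc(-c3ccncc3)c(-c3ccc(Cl)c(O)c3)n2)c1)Nc1cc(C(F)(F)F)cc(C(F)(F)F)c1` differs from compound 2 by hydrogen in place of methyl on an oxygen on an aromatic ring, methoxy to hydroxy. Among the measured compounds shown here, no single-change step between measured compounds exists to guide this. A modest weakening within or just beyond the scatter is expected, a 1.5-fold higher number from compound 2 to compound 3 (0.18 log units; within the scatter). Compound 3 is estimated at 1700 nM, between 700 nM and 4000 nM.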

Compound 3, concentration for 50% growth inhibition: 849 nM
Beside the measured number, compound 3's estimate is 2.0-fold (0.30 log units) above it; measured number inside the range.
By their numbers in this assay, from the lowest: compounds 3 and 2 (each within the scatter of the next); then compound 1.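

In this assay, methoxy to hydroxy on the 4-chloro-3-methoxyphenyl group gives a 1.3-fold lower number from compound 2 to compound 3 (0.12 log units; within the scatter) and so leaves the number within the scatter, which shows that this position tolerates loss of the methyl on the oxygen. Trifluoromethyl in place of hydrogen on an aromatic carbon gives a 3.7-fold lower number from compound 1 to compound 3 (0.57 log units; beyond the scatter) and is the first single change here to go beyond the scatter. No evidence at hand explains either step.

On these data alone, whether ethoxy or an amine at this position would keep the growth inhibition stays open. So does whether methoxy would match hydroxy in compound 1.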